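The compounds below may be only part of what the source reports. "The series", "measured", "known", "first", "only" and "open" are said of these compounds alone.

Compound 1 `Cc1ccccc1-c1nn(-c2ccc(F)cc2F)cc1CNC1CCN(S(C)(=O)=O)CC1` gives > 20000 nM in an ADME assay on Huh-7 cells (Homo sapiens) for cytotoxicity (on this read-out lower numbers stand for higher toxicity in this test and higher numbers for lower toxicity in this test), which is a limit of the assay. Compound 2 `Cc1ccccc1-c1nn(-c2ccc(N)cc2)cc1CNCCN1CCN(C)CC1` gives > 20000 nM in this assay, again a limit. Compound 3 `Cc1ccccc1-c1nn(Cc2ccc(F)cc2)cc1CNCCN1CCN(C)CC1` gives > 20000 nM in this assay, also a limit. So compound 3 stands only at a limit, and all three measured values sit at the limit of > 20000 nM in this assay, at which 3 of the 3 values shown sit. Within the data shown here, the one measured step, a step that the two limits leave unreadable from compound 2 to compound 3, is therefore unreadable in size. Compound 4 `Cc1ccccc1-c1nn(C(C)C)cc1CNCCN1CCN(C)CC1` differs from compound 3 by isopropyl in place of 4-fluorobenzyl on an aromatic nitrogen. Among the measured compounds shown here, no measured step of readable size bears on this change, and with every value at the limit no direction in this assay can be expected beyond the scatter. Compound 4 is estimated at 25000 nM, ranging from 12000 nM to 50000 nM, which means an expected step that the limit leaves unreadable from compound 3 to compound 4.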

Compound 4, half-maximal cytotoxic concentration: > 20000 nM
Compound 4 ended at the assay's limit; the forecaster's own chance of this, stated with the estimate: 80%; the middle value lies beyond the limit too.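

Neither step to compound 4, from compound 2 or from compound 3, can be read, because all the values shown stand at one limit: the limit of > 20000 nM in this assay, at which 4 of the 4 values shown sit. The compounds shown leave open whether any group on the aromatic nitrogen changes the read-out in this assay.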